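From benzyl to 4-chlorobenzyl on the shared core

This account rests on a few compounds, and the source may have more. Where it says the series, first, only, none or still open, it means among the compounds named here.

In a functional assay on BV-2 cells (Mus musculus), read by Griess assay, with a stated time of 24 h (a higher number here means a weaker inhibitor, a lower number a stronger inhibitor), compound 1 `O=C1C=CC2(C=C1)OCCC(=O)N2c1ccccc1` gives 1300 nM and compound 2 `C=CCC1COC2(C=CC(=O)C=C2)N(c2ccccc2)C1=O` gives 1030 nM as well. Compound 3 `O=C1C=CC2(C=C1)OCC(Cc1ccccc1)C(=O)N2c1ccccc1` gives 570 nM in this assay and so stands within the scatter of compound 2 and beyond the scatter of compound 1 on the lower side. The measured steps are a 1.3-fold lower number from compound 1 to compound 2 (0.10 log units; within the scatter) for allyl, a 2.3-fold lower number from compound 1 to compound 3 (0.36 log units; beyond the scatter) for benzyl and a 1.8-fold lower number from compound 2 to compound 3 (0.26 log units; within the scatter) between those two side chains.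

Compound 4 `O=C1C=CC2(C=C1)OCC(Cc1ccc(Cl)cc1)C(=O)N2c1ccccc1` differs from compound 3 by chloro in place of hydrogen on an aromatic carbon and has chloro in place of hydrogen on an aromatic carbon, so that benzyl becomes 4-chlorobenzyl. Going by the values given here, no measured step changes that aromatic ring, so the side-chain steps offer only a rough guide to size, and the largest of them is modest. No step beyond the scatter is therefore expected in this assay in either direction. The estimated step is a 1.1-fold lower number from compound 3 to compound 4 (0.06 log units; within the scatter) and remains uncertain. Compound 4 is expected at 500 nM with a range from 200 nM to 1200 nM on this estimate.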

Compound 4, half-maximal inhibitory concentration: 540 nM
Compound 4: middle estimate off by 1.1-fold (0.03 log units), on the low side; low and high end bracket the measured number.
By their numbers in this assay, from the lowest: compounds 4, 3, 2 and 1 (each within the scatter of the next, the first and the last beyond it).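

In this assay, going by these compounds alone, chloro in place of hydrogen on the side-chain aromatic ring gives a 1.1-fold lower number from compound 3 to compound 4 (0.02 log units; within the scatter), the first reading at this place on the ring, and this change to 4-chlorobenzyl leaves the number within the scatter. Measured against the allyl side chain, the new group gives a 1.9-fold lower number from compound 2 to compound 4 (0.28 log units; within the scatter), which also stays within the scatter. Measured against hydrogen on the saturated ring carbon, it gives a 2.4-fold lower number from compound 1 to compound 4 (0.38 log units; beyond the scatter), so 4-chlorobenzyl, like benzyl, stands beyond the scatter only from compound 1.

As far as these compounds go, whether a methoxy, an amine or a carboxylic acid in the same place, or a longer chain linking the aromatic ring to the shared core, would move the number remains open. No evidence at hand bears on this result.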